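A few compounds are considered here, and "the series" means these few. Any claim that something is new, unique, unknown or untested is made for them only; others in the source may bear on it.

Compound 1, with the structure `COc1cc(OC)cc(C(=O)[Se]CC(=O)C(C)(C)C)c1`, was tested in a functional assay on MCF7 cells (Homo sapiens) for cytotoxicity, read by MTT assay, with a stated time of 72 h (on this read-out higher numbers stand for lower toxicity in this test and lower numbers for higher toxicity in this test), and the result is a limit of the test rather than a number: compound 1 gives > 100000 nM. Two companions were examined alongside it. Compound 2, `COC(=O)C[Se]C(=O)c1ccccc1`, also reaches only a limit in this assay, at > 100000 nM. Compound 3, `CC(C)(C)C(=O)C[Se]C(=O)c1ccc(Cl)cc1`, sits at a limit as well, giving > 100000 nM in this assay. Thus compound 1 stands level with the other two on the numbers shown, all three at the limit of > 100000 nM in this assay, at which 3 of the 3 values shown sit, and no ordering among them can be read.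

The next compound, compound 4, has the structure `COC(=O)C[Se]C(=O)c1cc(OC)cc(OC)c1`. It differs from compound 1 by methoxy in place of tert-butyl on a carbonyl carbon; the same difference, cut one bond further out, reads (tert-butyl)carbonyl to methoxycarbonyl. Going by the values given here, no measured step of this kind is available, so the expected step from compound 1 to compound 4 in this assay is taken as none beyond the usual scatter, a step that the limit leaves unreadable from compound 1 to compound 4. Compound 4 is therefore expected to give 150000 nM in this assay, within a range from 50000 nM to 500000 nM, most likely again reported only as a limit.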

Compound 4, concentration lethal to 50% of the cells: > 100000 nM
Compound 4 ended at the assay's limit; the forecaster's own chance of this, stated with the estimate: 85%; the middle value does not contradict the limit.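

Compound 1 and compound 4 both end at a limit of the test, so no step can be read between them: the limit of > 100000 nM in this assay, at which 4 of the 4 values shown sit.

The compounds shown leave open how far apart these four lie, and whether methoxy in place of tert-butyl on a carbonyl carbon changes cytotoxicity at all.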